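This account rests on a few compounds, and the source may have more. Where it says the series, first, only, none or still open, it means among the compounds named here.

In a functional assay on Calu-3 cells (Homo sapiens) for cytotoxicity, read by WST assay, with a stated time of 72 h (on this read-out higher numbers stand for weaker inhibition and lower numbers for stronger inhibition), compound 1 (`Cn1c(-c2cc(-c3cccc(F)c3)on2)cc2ccccc21`) gives only a limit, > 100000 nM, and not a number. The other measured compound, compound 2 (`Fc1ccc(-c2cc(-c3ccc4[nH]ccc4c3)on2)cc1`), gives 16800 nM in this assay. Compound 3 (`COc1cccc(-c2cc(-c3cc4ccccc4n3C)no2)c1`) differs from compound 1 by methoxy in place of fluoro on an aromatic carbon. Among the measured compounds shown here, no measured pair shows this change, so the expected step that the limit leaves unreadable from compound 1 to compound 3 is taken as no more than the usual scatter, in either direction. Compound 3 is therefore expected to give about 120000 nM, within 40000 nM to 400000 nM, and most likely again only a limit.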

Compound 3, half-maximal inhibitory concentration: 17300 nM
Compound 3: middle estimate off by 6.9-fold (0.84 log units), on the high side, outside the stated range (below it).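

In this assay, methoxy in place of fluoro on an aromatic carbon, meta to a large group, gives an at least 5.7-fold lower number from compound 1 to compound 3 (0.76 log units; beyond the scatter). This shows that the read-out responds to the group at this position, which neither earlier compound could show. The true size of the step stays unknown because compound 1 stands at a limit: the limit of > 100000 nM in this assay, at which 1 of the 3 values shown sits.

The compounds shown leave open whether this step is particular to methoxy or would also appear with another group here, such as hydroxy, an amine or a longer alkoxy chain.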